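Swapping Phenyl for tert-Butyl on Two Related Cores

The compounds below may be only part of what the source reports. "The series", "measured", "known", "first", "only" and "open" are said of these compounds alone.

Of the compounds shown here, three have been measured in an ADME assay on Caco-2 cells (Homo sapiens) for permeability, read by LC-MS, in the apical to basolateral direction, with a stated time of 60 min, at pH 6.5 (on this read-out lower numbers stand for lower permeability and higher numbers for higher permeability), and a fourth awaits measurement. Compound 1 `O=C(NCc1cc(Cl)ccc1-n1cnnn1)[C@@H]1CC=NN1C(=O)[C@H](O)c1ccccc1` gives 7 10^-6 cm/s in this assay. Compound 3 `CC(C)(C)[C@@H](O)C(=O)N1N=CC[C@H]1C(=O)NCc1cc(Cl)ccc1-n1cnnn1` differs from compound 1 by tert-butyl in place of phenyl on a saturated chain carbon bound to a carbonyl carbon and an oxygen on a saturated carbon; in this assay compound 3 gives 15 10^-6 cm/s, and the step is a 2.1-fold higher number from compound 1 to compound 3 (0.33 log units; beyond the scatter). Compound 2 `O=C(NCc1cc(Cl)ccc1-n1cnnn1)[C@@H]1CCNN1C(=O)[C@H](O)c1ccccc1` carries the same phenyl group as compound 1 but sits on a different core; the difference between the two cores is not broken down here. In this assay compound 2 gives 5.3 10^-6 cm/s, and this value and that of compound 1 lie within the usual scatter of each other, so nothing can be said about an order between them.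

Compound 4 `CC(C)(C)[C@@H](O)C(=O)N1NCC[C@H]1C(=O)NCc1cc(Cl)ccc1-n1cnnn1` has not yet been measured. Among the compounds with values here, it differs from compound 2 by tert-butyl in place of phenyl on a saturated chain carbon bound to a carbonyl carbon and an oxygen on a saturated carbon, which is the same change as the one from compound 1 to compound 3, now made on the core of compound 2 instead of the core of compound 1. Because that change gave a 2.1-fold higher number from compound 1 to compound 3 (0.33 log units; beyond the scatter), a step of similar size is expected here, namely a 2.1-fold higher number from compound 2 to compound 4 (0.32 log units; beyond the scatter). This expectation rests on a single measured example of the change, so the range around it is kept wide. Compound 4 is estimated to give 11 10^-6 cm/s in this assay, with a likely span from 6 10^-6 cm/s to 20 10^-6 cm/s.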

Compound 4, apparent permeability: 7.2 10^-6 cm/s
The estimate for compound 4 lay 1.5-fold (0.18 log units) above the measured number; low and high end bracket the measured number.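

On the core of compound 2, putting tert-butyl in place of phenyl gives, in this assay, a 1.4-fold higher number from compound 2 to compound 4 (0.13 log units; within the scatter), so no order can be stated between these two compounds. Set side by side, the two examples of this change cannot be told apart, even though only the first step lies beyond the scatter: the same change on two cores in this assay, a 2.1-fold higher number (0.33 log units; beyond the scatter) from compound 1 to compound 3 and a 1.4-fold higher number (0.13 log units; within the scatter) from compound 2 to compound 4, 1.6-fold (0.20 log units) apart, within the scatter of two such steps This shows that the result on the core of compound 2 does not conflict with the step seen on the core of compound 1, but it does not prove that the change carries over with the same size, and it does not show that the core alters the step, since two pairs of compounds with this much scatter cannot separate those readings.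

What the compounds shown leave open is how this change behaves on any third core, where one more pair could show whether the step usually lies nearer the larger or the smaller example. They also leave open what an amine, a carboxylic acid or a longer chain would give in place of phenyl or tert-butyl on a saturated chain carbon bound to a carbonyl carbon and an oxygen.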